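The source may hold more compounds than are shown below. What is called first, only, known or untested is meant among the compounds shown, and "the series" means these compounds.

Three compounds of this series carry a measurement in a functional assay on the whole organism (strain albino) for inhibition, with Rattus norvegicus as the target, read by paw edema, with stated times of 30 min and 2 h, at a dose of 100 mg/kg by the oral route; on this read-out lower numbers stand for less inhibition and higher numbers for more inhibition at the one dose given (going by the name of the read-out). Compound 1, `COc1ccc(C2CC(c3ccc(OC)c(OC)c3)=NN2)c(OC)c1`, gives 39% there. Compound 2, `COc1ccc(C2=NN(C(=O)CBr)C(c3c(Cl)cccc3Cl)C2)cc1OC`, gives 58%, the largest of the three numbers as they stand. Compound 3, `COc1ccc(C2=NN(C(=O)CBr)C(c3c(Cl)cccc3Cl)C2)cc1`, gives 49%. Among the compounds with values here, the one pair that differs in a single place is compound 2 and compound 3, where hydrogen replaces methoxy on an aromatic carbon, and the step is a number 9 percentage points lower from compound 2 to compound 3 (within the scatter). Compound 2 thus has compound 3 nearest to it, inside the scatter, and compound 1 furthest, a gap beyond the scatter.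

The unmeasured compound 4, `COc1ccc(C2=NN(C(=O)CO[N+](=O)[O-])C(c3c(Cl)cccc3Cl)C2)cc1OC`, is reached from compound 2 by the change (nitrooxy in place of bromo on a saturated chain carbon bound to a carbonyl carbon). Within the data shown here, no measured step touches this part of the molecule: the only single-place step, from compound 2 to compound 3, concerns a methoxy group on an aromatic ring and was within the scatter. Nothing in the data therefore points to a move in either direction in this assay, and the expectation for compound 4 rests on compound 2 alone. Compound 4 is expected to give about 55%, within a range from 40% to 70%. That estimate means a step of a number 3 percentage points lower from compound 2 to compound 4 (within the scatter), expected to stay within the scatter.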

Compound 4, a percentage reported as inhibition, in the whole organism at one dose (the size of the read-out at that dose, not a potency): 49%
Estimate against measurement, compound 4: 6 percentage points above; low and high end bracket the measured number.
By their numbers in this assay, from the lowest: compounds 1, 3, 4 and 2 (each within the scatter of the next, the first and the last beyond it).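

Within the data shown here, this result is the first reading at the saturated chain carbon bound to a carbonyl carbon. In this assay, nitrooxy in place of bromo gives a number 9 percentage points lower from compound 2 to compound 4 (within the scatter), so the step stays within the scatter even though the entering group holds more heavy atoms and brings hydrogen-bond acceptors that bromo lacks. For this pair, then, bromo is not needed to keep the inhibition seen at the one dose, and nitrooxy can stand in its place without a change that can be told from the scatter. Nothing available bears on why these two groups read so closely.

Going by these compounds, it remains open whether other groups on this carbon, such as an amine, a carboxylic acid or a hydroxy group, or a longer chain carrying the nitrooxy, would also stay this close to compound 2. On these data alone, it is also open whether nitrooxy would read the same way on the core of compound 3, and whether compound 2 and compound 4 would separate at other doses.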